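An Ester in Place of an Amide: What to Expect

This account rests on a few compounds, and the source may have more. Where it says the series, first, only, none or still open, it means among the compounds named here.

Measured so far:
compound 1, `C/C=C1/[C@H](O[C@@H]2O[C@H](CO)[C@@H](O)[C@H](O)[C@H]2O)OC=C(C(=O)OC)[C@H]1CC(=O)NCCC`, in a functional assay on SK-BR-3 cells (Homo sapiens) for antiproliferative activity, read by MTT assay, with a stated time of 72 h; a higher number here means a weaker inhibitor, a lower number a stronger inhibitor: > 20000 nM
compound 2, `C#CCOC(=O)C[C@@H]1C(C(=O)OC)=CO[C@@H](O[C@@H]2O[C@H](COC(C)=O)[C@@H](OC(C)=O)[C@H](OC(C)=O)[C@H]2OC(C)=O)/C1=C/C`, in this assay: > 15000 nM

Both values are limits of the assay, not numbers. Compound 1 sits at the limit of > 20000 nM in this assay, at which 1 of the 2 values shown sits, so no inhibition was seen in the range tested. Compound 2 sits at the limit of > 15000 nM in this assay, at which 1 of the 2 values shown sits, again only a limit. Where compound 1 stands is therefore known only as a limit, and the one other value shown is a limit as well; nothing here separates the two compounds or ranks them.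

Compound 3, `C/C=C1/[C@H](O[C@@H]2O[C@H](CO)[C@@H](O)[C@H](O)[C@H]2O)OC=C(C(=O)OC)[C@H]1CC(=O)OCCC(C)C`, differs from compound 1 in one place: isopentyloxy in place of propylamino on a carbonyl carbon. For the measured compounds named here, no step between two measured compounds is available, so the size of this change cannot be calibrated from the data. Because compound 1 gives only a limit > 20000 nM, the change could at most reveal a gain; a loss would be hidden by the limit. With both measured compounds inactive, the expected step is a number no higher from compound 1 to compound 3 (the limit leaves the size open), that is, none beyond the scatter. Compound 3 is expected to give 20000 nM, in a range from 8000 nM to 50000 nM, most probably again reported only as a limit.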

Compound 3, half-maximal inhibitory concentration: 9020 nM
The estimate for compound 3 lay 2.2-fold (0.35 log units) above the measured number; measured number inside the range.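

Of the three compounds, only compound 3 gives a number rather than a limit in this assay, so the group on this carbonyl carbon can decide whether any activity is seen at all. Isopentyloxy in place of propylamino gives an at least 2.2-fold lower number from compound 1 to compound 3 (0.34 log units; beyond the scatter), which shows that this place on the shared core responds to change and that the ester-bearing compound 3 is not as inactive as the amide compound 1. The true size of the step stays open because compound 1 carries only a limit of the assay, not a number: the limit of > 20000 nM in this assay, at which 1 of the 3 values shown sits.

The swap alters two things at once, the atom joined to the carbonyl (oxygen for nitrogen) and the chain (isopentyl for propyl), so a propyloxy group or an isopentylamino group on the same carbon would be needed to tell which of the two matters. As far as these compounds go, whether a longer chain or a carboxylic acid here would do better also remains unknown, and compound 2 differs from the others in more than one place, so steps to it cannot be read.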